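This account rests on a few compounds, and the source may have more. Where it says the series, first, only, none or still open, it means among the compounds named here.

Compound 2 `Nc1scc(CN2CCN(c3ccc(Cl)c(C(F)(F)F)c3)CC2)c1C(=O)c1ccc(Cl)cc1` gives -60% in a functional assay on CHO cells with adenosine receptor A1 (Homo sapiens) as the target, read by cAMP accumulation and immunoassay, with a stated time of 6 min, tested at 10 uM (a higher number here means a weaker effect of the compound at the concentration tested, a lower number a stronger effect), and so stands level with compound 1 `Nc1scc(CN2CCN(c3ccccc3C(F)(F)F)CC2)c1C(=O)c1ccc(Cl)cc1`, which gives -60% in this assay; together they are the highest of the three numbers, and compound 3 `Nc1scc(CN2CCC(c3ccc(Cl)cc3)CC2)c1C(=O)c1ccc(Cl)cc1` gives -61% in this assay, within the scatter of both. Among the compounds with values here, the one measured step that bears on a group on the amine nitrogen in the ring is no change at the digits printed from compound 1 to compound 2 (within the scatter), which showed no change beyond the scatter. Compound 4 `Nc1scc(CN2CCN(c3ccc(F)c(F)c3)CC2)c1C(=O)c1ccc(Cl)cc1` differs from compound 2 as follows: 3,4-difluorophenyl in place of 4-chloro-3-(trifluoromethyl)phenyl on an amine nitrogen in a ring. From that step, no change beyond the scatter is expected, so the estimated step is a number 2 percentage points higher from compound 2 to compound 4 (within the scatter). Compound 4 is therefore expected to give about -58% in this assay, within a range from -75% to -40%.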

Compound 4, a percentage reported as activity, at one concentration (the size of the read-out at that concentration, not a potency): -87%
Beside the measured number, compound 4's estimate is 29 percentage points above it, and the stated range ends above it.
By their numbers in this assay, from the lowest: compound 4; then compounds 3, 1 and 2 (each within the scatter of the next).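

Swapping one trifluoromethyl-bearing phenyl for another on the amine nitrogen in a ring had moved nothing, but in this assay 3,4-difluorophenyl in place of 4-chloro-3-(trifluoromethyl)phenyl gives a number 27 percentage points lower from compound 2 to compound 4 (beyond the scatter), and in place of 2-(trifluoromethyl)phenyl gives a number 27 percentage points lower from compound 1 to compound 4 (beyond the scatter). The read-out at this position therefore does respond to the group carried there, towards a stronger effect at the concentration tested. Nothing available explains this step. The compounds shown leave open whether a phenyl with a single fluorine would behave like compound 4, and where an unsubstituted phenyl or a methoxyphenyl would fall.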